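Methoxyethyl Amine in Place of the Branched Pentyl

This account rests on a few compounds, and the source may have more. Where it says the series, first, only, none or still open, it means among the compounds named here.

Three compounds on a shared core were measured in an assay on HEK293 cells for displacement of a labelled ligand from corticotropin-releasing factor receptor 1 (Homo sapiens), with a stated time of 2 h; a lower number here means a stronger inhibitor, a higher number a weaker inhibitor. Compound 1 `COCc1cc(OC)c(-c2nc3c(C)ccc(N(C)C)c3cc2C)c(OC)c1` gives 212 nM in this assay. Compound 2 `COCc1cc(OC)c(-c2nc3c(C)ccc(N(CC4CC4)CC4CC4)c3cc2C)c(OC)c1` gives 88 nM in this assay, and a 2.4-fold lower number from compound 1 to compound 2 (0.38 log units; beyond the scatter). Compound 3 `CCC(CC)Nc1ccc(C)c2nc(-c3c(OC)cc(COC)cc3OC)c(C)cc12` reaches only a limit of the assay, > 1000 nM in this assay, which is the limit of > 1000 nM in this assay, at which 1 of the 3 values shown sits. Among the numbers shown compound 3 thus stands at the weak end: an at least 4.7-fold higher number from compound 1 to compound 3 (0.67 log units; beyond the scatter) and an at least 11-fold higher number from compound 2 to compound 3 (1.05 log units; beyond the scatter).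

Compound 4 `COCCNc1ccc(C)c2nc(-c3c(OC)cc(COC)cc3OC)c(C)cc12` differs from compound 3 in one place: 2-methoxyethyl in place of pentan-3-yl on a nitrogen on an aromatic ring. All three measured steps bear on this position, since each of them changes the group on the same nitrogen, yet each swaps between a branched pentan-3-yl and a nitrogen carrying two groups, whereas the 2-methoxyethyl keeps a single chain on the nitrogen. The steps give no measured direction for this particular exchange, and compound 3 itself is only a limit, so the starting point is uncertain. Compound 4 is therefore expected near 800 nM, with a range from 200 nM to 3000 nM. The expected step in this assay is an at least 1.2-fold lower number from compound 3 to compound 4 (0.09 log units; that floor lies within the scatter), with a real chance that the assay again reports only a limit.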

Compound 4, half-maximal inhibitory concentration: > 1000 nM
Compound 4 ended at the assay's limit; the forecaster's own chance of this, stated with the estimate: 40%; middle value at least 1.2-fold (0.09 log units) from the limit.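

In this assay the result for compound 4 is a limit of the assay, and so is the result for compound 3, so the step between them cannot be read: the limit of > 1000 nM in this assay, at which 2 of the 4 values shown sit. What compound 4 adds is a second compound with a single chain on the nitrogen that lies on the weak side of both compounds with two groups there, with an at least 11-fold higher number from compound 2 to compound 4 (1.05 log units; beyond the scatter) and an at least 4.7-fold higher number from compound 1 to compound 4 (0.67 log units; beyond the scatter). Among these four compounds, the split therefore follows the number of groups on the nitrogen, with none going against it, and exchanging pentan-3-yl for 2-methoxyethyl, which brings in one hydrogen-bond acceptor, does not bring the value inside the limit.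

The compounds shown leave open how far apart compound 3 and compound 4 really lie, and whether the single chain itself, rather than the particular chains tested, sets the split. Going by these compounds alone, a (cyclopropylmethyl)amino group would carry one of the chains of compound 2 as the only group on the nitrogen, and a bis(2-methoxyethyl)amino group would carry the chain of compound 4 twice, so the two would approach that question from opposite sides.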